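Methyl to ethyl on the aromatic nitrogen of compound 3

A few compounds are considered here, and "the series" means these few. Any claim that something is new, unique, unknown or untested is made for them only; others in the source may bear on it.

Measured in an assay on isolated protein for inhibition of Discoidin domain-containing receptor 2 (Homo sapiens), read by ELISA, with a stated time of 60 min; a higher number here means a weaker inhibitor, a lower number a stronger inhibitor:
compound 1 `Cc1ccc(C(=O)Nc2cc(CN3CCN(C4CCCC4)CC3)cc(C(F)(F)F)c2)cc1-c1ccc2cn[nH]c2c1` gives 7 nM
compound 2 `Cc1ccc(C(=O)Nc2cccc(C(F)(F)F)c2)cc1-c1ccc2c(-c3cn[nH]c3)n[nH]c2c1` gives 55.6 nM
compound 3 `Cc1ccc(C(=O)Nc2cccc(C(F)(F)F)c2)cc1-c1ccc2c(-c3cnn(C)c3)n[nH]c2c1` gives 4.4 nM

Compound 3 has the lowest number of the three. Compound 1 stands nearest, within the scatter, so nothing separates the two. Within the data shown here, compound 2 stands furthest; the single one-place step is a 13-fold lower number from compound 2 to compound 3 (1.10 log units; beyond the scatter), well beyond the scatter.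

Compound 4 `CCn1cc(-c2n[nH]c3cc(-c4cc(C(=O)Nc5cccc(C(F)(F)F)c5)ccc4C)ccc23)cn1` is not yet measured in this assay. Its difference from compound 3 is methyl in place of hydrogen on a saturated chain carbon bound to an aromatic nitrogen.

Among the measured compounds shown here, only the step from compound 2 to compound 3 touches the same site. For the measured compounds named here, it shows that placing a methyl on that aromatic nitrogen lowers the number strongly, but it is a hydrogen-to-methyl change, not a methyl-to-ethyl one, and no pair among the measured compounds extends a substituent by one carbon at this position. The direction of a further extension is therefore not shown by the data, and the expected step of a 1.1-fold higher number from compound 3 to compound 4 (0.06 log units; within the scatter) is estimated to lie within the scatter, with no confident direction.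

For compound 4 the number in this assay is estimated at 5 nM, expected between 2 nM and 15 nM.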

Compound 4, half-maximal inhibitory concentration: 2.6 nM
Beside the measured number, compound 4's estimate is 1.9-fold (0.28 log units) above it; the range from low to high includes it.
By their numbers in this assay, from the lowest: compounds 4, 3 and 1 (each within the scatter of the next, the first and the last beyond it); then compound 2.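

In this assay, the change from methyl to ethyl on the aromatic nitrogen gives a 1.7-fold lower number from compound 3 to compound 4 (0.23 log units; within the scatter), so the added methyl on the saturated chain carbon bound to an aromatic nitrogen does not separate the two compounds. The effect of replacing hydrogen on that aromatic nitrogen is therefore not confined to methyl: ethyl gives a 21-fold lower number from compound 2 to compound 4 (1.33 log units; beyond the scatter), and this sits alongside the earlier 13-fold lower number from compound 2 to compound 3 (1.10 log units; beyond the scatter), so both alkyl groups leave the number far under that of compound 2. No measurement is available that accounts for this tolerance of one extra carbon or for the large step away from hydrogen.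

Still open, as far as these compounds go, is how far this tolerance extends on that nitrogen: a longer chain such as propyl, a branched isopropyl group, or a chain ending in an amine or a carboxylic acid could hold the number in this range or could raise it. Also open, from the compounds shown here alone, is whether the 1-ethyl-1H-pyrazol-4-yl group gives a similar result on a core carrying the cyclopentyl-substituted side group of compound 1, and whether the pattern holds outside this assay.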